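The compounds below may be only part of what the source reports. "The series", "measured", "known", "first", "only" and "open" are said of these compounds alone.

Working notes on the series.

Compound 1 `CCCCCCCCc1ccc(CCC(N)(CO)C(=O)O)cc1` is tested in a functional assay on the whole organism (spleen, spleen) with Rattus norvegicus as the target; a higher number here means that more compound is needed for the effect, a lower number that less compound is needed. In this assay compound 1 reaches only the limit of > 10 mg/kg, a boundary of the measurement rather than a number; the limit of > 10 mg/kg in this assay, at which 1 of the 2 values shown sits, describes where it sits. Compound 2 `CCCCCCCOc1ccc(CCC(N)(CO)C(C)C)cc1` is the other measured member, and in this assay compound 2 gives 4.5 mg/kg. Going by the values given here, no step between the two measured compounds is available, so their values are stated side by side and nothing more.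

Compound 3 `CCCCCCCCc1ccc(CCC(C)(N)CCO)cc1` is not yet measured. It differs from compound 1 by a group of 6 heavy atoms (4 carbon, 1 nitrogen, 1 oxygen; no ring) in place of a group of 7 heavy atoms (3 carbon, 1 nitrogen, 3 oxygen; no ring), on a saturated chain carbon, two bonds along the chain from an aromatic carbon. The shared core of compound 1 carries this replacement on a saturated chain carbon, two bonds along the chain from an aromatic carbon.

For compound 3 a step downward beyond the usual scatter is expected, meaning less compound needed, of size an at least 3.3-fold lower number from compound 1 to compound 3 (0.52 log units; beyond the scatter). The estimate for compound 3 in this assay is 3 mg/kg, with an expected range from 1 mg/kg to 10 mg/kg.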

Compound 3, dose for 50% inhibition: > 10 mg/kg
Compound 3: no number, only a limit (the forecaster's own chance of this, stated with the estimate: 25%); middle value at least 3.3-fold (0.52 log units) from the limit.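

No step can be read from compound 1 to compound 3, as each of the two stands only at a limit of the assay, not at a number: the limit of > 10 mg/kg in this assay, at which 2 of the 3 values shown sit.

The compounds shown leave open whether this replacement on the saturated chain carbon changes the effect at all, and in which direction.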